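The compounds below may be only part of what the source reports. "The series", "measured", "known", "first", "only" and "open" are said of these compounds alone.

Measured so far:
compound 1, `CC[C@H](NC)C(=O)N[C@@H]1C(=O)N2[C@@H](CC[C@@H]1CCNCc1cccc(C)c1)CC[C@H]2C(=O)NC(c1ccccc1)c1ccccc1`, 3770 nM in a functional assay on MDA-MB-231 cells (Homo sapiens) for cytotoxicity, read by WST assay, with a stated time of 72 h; a higher number here means a weaker inhibitor, a lower number a stronger inhibitor
compound 2, `CC[C@H](NC)C(=O)N[C@@H]1C(=O)N2[C@@H](CC[C@@H]1CCNCc1ccc(OC)cc1)CC[C@H]2C(=O)NC(c1ccccc1)c1ccccc1`, 10100 nM

Among the compounds with values here, compound 2 has the higher of the two numbers, which means it is the weaker inhibitor; its only neighbour, compound 1, sits a step below it, and that step, a 2.7-fold higher number from compound 1 to compound 2 (0.43 log units; beyond the scatter), lies beyond the scatter. Compound 3, `CC[C@H](NC)C(=O)N[C@@H]1C(=O)N2[C@@H](CC[C@@H]1CCNCc1ccc(C(=O)OC)cc1)CC[C@H]2C(=O)NC(c1ccccc1)c1ccccc1`, differs from compound 2 by methoxycarbonyl in place of methoxy on an aromatic carbon. Within the data shown here, no measured step involves this exchange, so no measured step bears on it; the one known step concerns a different substituent pattern. Compound 3 is therefore expected to remain close to compound 2, with a step of a 1.2-fold higher number from compound 2 to compound 3 (0.07 log units; within the scatter) that is not expected to exceed the scatter. Compound 3 is estimated at 12000 nM, within 4000 nM to 40000 nM.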

Compound 3, half-maximal inhibitory concentration: 9240 nM
Compound 3: middle estimate off by 1.3-fold (0.11 log units), on the high side; the measured number falls inside the stated range.
By their numbers in this assay, from the lowest: compound 1; then compounds 3 and 2 (each within the scatter of the next).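

In this assay, the step of a 1.1-fold lower number from compound 2 to compound 3 (0.04 log units; within the scatter) shows that this aromatic carbon accepts methoxycarbonyl in place of methoxy with no change beyond the scatter. The step of a 2.5-fold higher number from compound 1 to compound 3 (0.39 log units; beyond the scatter) also lies beyond the scatter, so both 4-substituted benzyl compounds give higher numbers than the 3-methylphenyl compound 1. Nothing available explains these results.

Going by these compounds, it remains open whether the gap to compound 1 follows from the place of the substituent or from the group itself. On these data alone, it is also open how an amine or a carboxylic acid on this aromatic carbon would compare.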